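The compounds below may be only part of what the source reports. "The series", "measured", "known", "first", "only" and "open" are said of these compounds alone.

Measured so far in a functional assay on HCT-15 cells (Homo sapiens) for cytotoxicity, in the presence of a further agent that is not named here; a higher number here means a weaker inhibitor, a lower number a stronger inhibitor
- Compound 1 `Clc1ccc(-c2cc(-c3ccsc3)nc(-c3ccco3)c2)o1` gives > 50000 nM as a limit of the assay, not a number
- Compound 2 `Cc1cccc(-c2cc(-c3ccc(Cl)o3)cc(-c3ccsc3)n2)c1` gives 21700 nM
- Compound 3 `Clc1ccc(-c2cc(-c3ccc(Cl)o3)cc(-c3ccsc3)n2)cc1` gives 5190 nM

Compound 3 stands lowest of the three, with 5190 nM as the strongest reading so far. The closest measured number lies a 4.2-fold lower number from compound 2 to compound 3 (0.62 log units; beyond the scatter) and is thus clearly separated. The remaining compound offers only a bound for comparison.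

Compound 4 `Cc1ccc(-c2cc(-c3ccc(Cl)o3)cc(-c3ccsc3)n2)o1` has not yet been measured. It carries 5-methylfuran-2-yl in place of 4-chlorophenyl on an aromatic carbon, next to the ring nitrogen, and the count of that change reads (5-methylfuran-2-yl in place of 4-chlorophenyl on an aromatic carbon).

The best guide is the earlier change at this same place. Replacing furan-2-yl with 4-chlorophenyl gave an at least 9.6-fold lower number from compound 1 to compound 3 (0.98 log units; beyond the scatter), and replacing it with 3-methylphenyl gave an at least 2.3-fold lower number from compound 1 to compound 2 (0.36 log units; beyond the scatter). Both steps lowered the number, whereas compound 4 goes from the phenyl ring back to a furan. For the measured compounds named here, no measured compound carries the 5-methylfuran-2-yl group, so the size remains uncertain. A modest rise in this assay is therefore expected, and the expected step is a 3.9-fold higher number from compound 3 to compound 4 (0.59 log units; beyond the scatter). Compound 4 is estimated at 20000 nM, with an expected range from 7000 nM to 50000 nM.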

Compound 4, half-maximal inhibitory concentration: > 50000 nM
Compound 4 ended at the assay's limit (the forecaster's own chance of this, stated with the estimate: 30%); middle value at least 2.5-fold (0.39 log units) away from the limit.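

In this assay, putting 5-methylfuran-2-yl in place of 4-chlorophenyl next to the ring nitrogen gives an at least 9.6-fold higher number from compound 3 to compound 4 (0.98 log units; beyond the scatter), and putting it in place of 3-methylphenyl gives an at least 2.3-fold higher number from compound 2 to compound 4 (0.36 log units; beyond the scatter). A methyl group on the furan therefore does not restore what the two phenyl rings gave at this position: among the four compounds, the two with a furan here, compound 1 and compound 4, both sit at a limit of the assay rather than at a number, while the two with a phenyl ring, compound 2 and compound 3, give readable values. The step from compound 1 to compound 4, methyl in place of hydrogen, cannot be read, and the two steps above give only a lower bound on their size, for one shared reason: the limit of > 50000 nM in this assay, at which 2 of the 4 values shown sit.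

The compounds shown leave open whether the six-membered ring alone accounts for the lower numbers, or whether its chlorine or methyl group is also needed, which a plain phenyl ring would test. They also leave open how this position responds to an amine or a carboxylic acid on that phenyl ring.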